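Hydroxy to chloro on the fused ring of compound 2

This account rests on a few compounds, and the source may have more. Where it says the series, first, only, none or still open, it means among the compounds named here.

Measured so far:
compound 1 `COc1cccc2occ(Cc3coc4ccccc4c3=O)c(=O)c12` gives 3490 nM
compound 2 `O=c1c(Cc2coc3cccc(OCC4CCCCC4)c3c2=O)coc2cc(O)ccc12` gives 4250 nM
compound 3 `O=C1c2c(OCC3CCCCC3)cccc2OCC1Cc1coc2ccccc2c1=O` gives 9380 nM

These values come from a functional assay on PC-3 cells (Homo sapiens) for antiproliferative activity, read by XTT assay; on this read-out lower numbers stand for stronger inhibition and higher numbers for weaker inhibition. Compound 2 stands second highest of the three; its number sits within the scatter of compound 1 and lies beyond the scatter of compound 3, which gives the weakest inhibition shown.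

Compound 4 `O=c1c(Cc2coc3cccc(OCC4CCCCC4)c3c2=O)coc2cc(Cl)ccc12` has not yet been measured. It differs from compound 2 in one place: chloro in place of hydroxy on an aromatic carbon. Within the data shown here, no measured pair shows this kind of exchange, so the direction of the step is open. A modest shift, if any, is expected. Compound 4 is estimated at 3500 nM, with a range from 1200 nM to 10000 nM, meaning an expected step of a 1.2-fold lower number from compound 2 to compound 4 (0.08 log units; within the scatter).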

Compound 4, half-maximal inhibitory concentration: > 10000 nM
Compound 4: a limit, no number; the forecaster's own chance of this, stated with the estimate: 5%; at least 2.8-fold (0.45 log units) between middle value and limit.
By their numbers in this assay, from the lowest: compounds 1 and 2 (each within the scatter of the next); then compound 3. At a limit, above all of these: compound 4.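

In this assay compound 4 gives > 10000 nM and this is a limit of the assay, not a number: the limit of > 10000 nM in this assay, at which 1 of the 4 values shown sits. Chloro in place of hydroxy on this aromatic carbon is not a neutral exchange, as it brings an at least 2.3-fold higher number from compound 2 to compound 4 (0.37 log units; beyond the scatter) and so shows, as no earlier pair could, that activity here responds to what sits at this position.

Only hydroxy and chloro are shown at this position, so it stays open whether hydroxy helps or chloro harms. An amine or a methoxy on the same carbon could help separate the two.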